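The source may report more compounds than this note shows. Statements on the series, on what has been measured and on what is new or still open speak of the compounds shown alone.

Values in a functional assay on the whole organism (strain Sprague-Dawley) for inhibition, with Rattus norvegicus as the target, with a stated time of 10 min (a lower number here means that less compound is needed, a higher number that more compound is needed for the effect), for the measured compounds
Compound 1 `CCOC(=O)c1cnc(-c2ccccc2OCC)[nH]c1=O` at 2 mg/kg
Compound 2 `CCOC(=O)c1cnc(-c2cc(OC)ccc2OC)[nH]c1=O` at 5 mg/kg
Compound 3 `CCOC(=O)c1cnc(-c2cc(Cl)ccc2OCC)[nH]c1=O` at 0.5 mg/kg

Compound 3 at 0.5 mg/kg stands lowest of the three numbers. Compound 4 `CCOC(=O)c1cnc(-c2cc(OC)ccc2OCC)[nH]c1=O` carries methoxy in place of chloro on an aromatic carbon, para to an ethoxy group (methoxy in place of chloro on an aromatic carbon). For the measured compounds named here, the one measured step at this place (a 4.0-fold lower number from compound 1 to compound 3 (0.60 log units; beyond the scatter)) came with chloro in place of hydrogen, and no measured step compares methoxy with chloro. Compound 2 also carries methoxy there and gives 5 mg/kg but lacks the ethoxy group. Much of the gain from chloro is therefore expected to be lost, so a higher number is expected in this assay with an estimated size of similar order (a 3.0-fold higher number from compound 3 to compound 4 (0.48 log units; beyond the scatter)). The estimated value for compound 4 is 1.5 mg/kg (expected range 0.5 mg/kg to 5 mg/kg).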

Compound 4, dose for 50% inhibition: 0.3 mg/kg
Compound 4: the middle estimate sits 5.0-fold (0.70 log units) above what was measured; measured number below the stated range.
By their numbers in this assay, from the lowest: compounds 4 and 3 (each within the scatter of the next); then compound 1; then compound 2.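

Chloro holds no special standing at this place: in this assay, the change to methoxy gives a 1.7-fold lower number from compound 3 to compound 4 (0.22 log units; within the scatter), so the two groups cannot be told apart, and methoxy also compares well with hydrogen, with a 6.7-fold lower number from compound 1 to compound 4 (0.82 log units; beyond the scatter). With methoxy held at this place, methyl in place of hydrogen on the chain bound to the oxygen gives a 17-fold lower number from compound 2 to compound 4 (1.22 log units; beyond the scatter). No evidence is available that accounts for these steps.

As far as these compounds go, whether this place tolerates an amine or a carboxylic acid remains open. So does the effect of a longer chain in place of the ethoxy group.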